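Diastereomer swap in a weakly active series

The source may report more compounds than this note shows. Statements on the series, on what has been measured and on what is new or still open speak of the compounds shown alone.

The series is weakly active throughout. Compound 1 `CC(=O)CC/C=C(\C)CCC1=C(C)CCCC1(C)C` is the open-chain ketone; in a functional assay on HCT-15 cells (Homo sapiens) for inhibition (on this read-out higher numbers stand for weaker inhibition of growth and lower numbers for stronger inhibition of growth), compound 1 returns only a limit, > 15000 nM. Compound 2 `C=C1CCCC(C)(C)C1CC[C@]1(C)CC[C@@H]([C@@H](C)C(=O)O)OO1` carries the free carboxylic acid. In this assay compound 2 likewise returns a limit, > 10000 nM, so its standing rests at the limit of > 10000 nM in this assay, at which 1 of the 3 values shown sits, rather than on a number. Among the compounds with values here, compound 3 `C=C1CCCC(C)(C)C1CC[C@]1(C)CC[C@H]([C@@H](C)C(=O)OC)OO1`, the methyl ester, is the only member with a measured number, giving 13100 nM in this assay. Since compound 2 stands at a limit, compound 2 and compound 3 cannot be ordered against each other.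

Compound 4 `C=C1CCCC(C)(C)C1CC[C@@]1(C)CC[C@H]([C@@H](C)C(=O)O)OO1` is a diastereomer of compound 2: the two compounds have the same atoms and bonds; at least one stereo element is drawn with a configuration in one of them and without one in the other: 2 of 4 stereo elements differ; a stereocentre at a saturated ring carbon is drawn R in compound 2 and S in compound 4; a stereocentre at a saturated ring carbon is drawn S in compound 2 and R in compound 4. Within the data shown here, no step between two measured compounds is available in this set to calibrate such a change. Among the measured compounds shown here, compound 2 sits at the limit of > 10000 nM in this assay, at which 1 of the 3 values shown sits, and compound 1 at the limit of > 15000 nM in this assay, at which 1 of the 3 values shown sits, and nothing among the three measured members indicates that swapping two ring centres moves growth inhibition far. The step in this assay is therefore expected to stay within the scatter, a step that the limit leaves unreadable from compound 2 to compound 4. Compound 4 is estimated at 12000 nM, within 4000 nM to 30000 nM. A further limit rather than a number is the likelier outcome for compound 4.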

Compound 4, concentration for 50% growth inhibition: 10700 nM
The estimate for compound 4 lay 1.1-fold (0.05 log units) above the measured number; low and high end bracket the measured number.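

In this assay, within the data shown here, compound 2 gives only a limit, > 10000 nM, so no step to compound 4 can be read from this pair. From the compounds shown here alone, whether the two ring centres that differ between compound 2 and compound 4 affect growth inhibition at all, and by how much, stays open.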